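A few compounds are considered here, and "the series" means these few. Any claim that something is new, unique, unknown or untested is made for them only; others in the source may bear on it.

Series notes. Compound 1 `CC(C)(C)Cc1c(-c2c(F)cccc2F)sc(N)c1C(=O)c1ccc(Cl)cc1`, compound 2 `CC(C)(C)Cc1c(-c2ccccc2)sc(N)c1C(=O)c1ccc(Cl)cc1` and compound 3 `CC(C)(C)Cc1c(-c2ccccc2)sc(N)c1C(=O)c1ccccc1Cl` share one core and differ only in their two aryl groups. In an assay on CHO cells for displacement of a labelled ligand from adenosine receptor A3 (Homo sapiens), read by scintillation counting, tested at 10 uM (on this read-out higher numbers stand for more inhibition at the one concentration tested (going by the name of the read-out) and lower numbers for less inhibition), compound 1 gives 1%, compound 2 gives 1% and compound 3 gives 1%. The two measured steps, no change at the digits printed from compound 1 to compound 2 (within the scatter) and no change at the digits printed from compound 2 to compound 3 (within the scatter), both lie within the scatter, so neither aryl exchange has moved the read-out. Compound 3 therefore stands level with compounds 1 and 2, with no ordering among the three.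

Compound 4 `CC(C)(C)Cc1c(-c2ccccc2)sc(N)c1C(=O)c1ccc(Cl)cc1Cl` is still to be measured. It differs from compound 3 in one place: chloro in place of hydrogen on an aromatic carbon. Among the compounds with values here, no measured step adds a chloro to the ring on the carbonyl carbon. The nearest in kind is the exchange of 4-chlorophenyl for 2-chlorophenyl, no change at the digits printed from compound 2 to compound 3 (within the scatter), which stayed within the scatter, and the exchange on the other aryl, no change at the digits printed from compound 1 to compound 2 (within the scatter), also stayed within the scatter. Nothing in the series shows a change of this sort shifting the read-out, and all three measured values are alike. The expected step of a number 1 percentage points higher from compound 3 to compound 4 (within the scatter) is accordingly none beyond the scatter. For compound 4 a value of 2% is estimated, in the range -8% to 15%.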

Compound 4, a percentage reported as inhibition, at one concentration (the size of the read-out at that concentration, not a potency): 1%
Compound 4: middle estimate off by 1 percentage points, on the high side; the range from low to high includes it.
By their numbers in this assay, from the lowest: compounds 1, 2, 3 and 4 (each within the scatter of the next).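

In this assay, within the data shown here, the added chloro gives no change at the digits printed from compound 3 to compound 4 (within the scatter), the first step that adds a group to the ring on the carbonyl carbon rather than exchanging one chlorophenyl for the other, and so 2-chlorophenyl to 2,4-dichlorophenyl leaves the read-out within the scatter. Reached from the other chlorophenyl, the same 2,4-dichlorophenyl ring gives no change at the digits printed from compound 2 to compound 4 (within the scatter), so at this level of inhibition the chloro shows no effect on the read-out from either starting point, whether it enters at the place meta to a chloro group or at the second place on that ring. Nothing at hand bears on why the read-out stays level across these changes.

Open, on these data alone, is whether a group of another kind at this place, such as a carboxylic acid, an amine or a methoxy, would give a read-out that stands apart from compound 4 at 1%. Also open, as far as these compounds go, is whether any change to the shared core outside the two aryl groups, for example a shorter chain in place of its branched alkyl group, would move this assay beyond the scatter.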